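A few compounds are considered here, and "the series" means these few. Any claim that something is new, unique, unknown or untested is made for them only; others in the source may bear on it.

Measured so far:
- compound 1, `Cc1cc(NC(=O)CN2CCC(c3cccc[n+]3[O-])CC2)ccc1F`: 18 nM
- compound 2, `Cc1cccc(NC(=O)CN2CCC(c3ccc(O)cn3)CC2)c1`: 3.8 nM
- compound 3, `COc1cccc(C)c1NC(=O)CN1CCC(c2ccccn2)CC1`: 40 nM

Three compounds sharing a core have been run in a functional assay on HEK293 cells for agonist activity at D(4) dopamine receptor (Homo sapiens), read by FLIPR; a higher number here means that more compound is needed for the effect, a lower number that less compound is needed. Compound 1 sits second highest of the three numbers. Its nearest neighbour is compound 3, whose number in this assay is higher by a margin beyond the usual scatter, and the furthest is compound 2, whose number is lower by a margin that is also beyond the scatter. Going by the values given here, no pair among the three differs in only one place, so none of the gaps can be tied to a single change.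

Compound 4, `Cc1ccc(Cl)cc1NC(=O)CN1CCC(c2cccc[n+]2[O-])CC1`, has not yet been measured in this assay. It differs from compound 1 in one place: 5-chloro-2-methylphenyl in place of 4-fluoro-3-methylphenyl on an amide-type nitrogen. Both groups that leave and enter carry one halogen and one methyl on a single carbon-only ring, and neither adds or removes a donor or acceptor, so compound 4 keeps the same core and the same charged heteroaryl as compound 1.

Among the compounds with values here, without a measured step that swaps only this group, the expectation rests on compound 1 itself. The step from compound 1 to compound 4 is expected to be small, a 1.4-fold higher number from compound 1 to compound 4 (0.14 log units; within the scatter), towards a slightly higher number and likely within the scatter. Compound 4 is therefore estimated at 25 nM, with a range from 8 nM to 80 nM.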

Compound 4, half-maximal effective concentration: 126 nM
Estimate against measurement, compound 4: 5.0-fold (0.70 log units) below; the whole stated range lies below it.
By their numbers in this assay, from the lowest: compound 2; then compound 1; then compound 3; then compound 4.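

In this assay, going by these compounds alone, 5-chloro-2-methylphenyl in place of 4-fluoro-3-methylphenyl on an amide-type nitrogen gives a 7.0-fold higher number from compound 1 to compound 4 (0.85 log units; beyond the scatter) and is the first gap in this set that can be tied to a single change. The two groups have the same number of heavy atoms, the same carbon-only ring and no hydrogen-bond donors or acceptors, so these counts alone do not settle the outcome at this place; the groups differ in their halogen and in where the halogen and methyl stand on the ring. No measurement at hand explains the step.

The compounds shown cannot separate the change of halogen from the change in where the two groups stand, and the 4-fluoro-3-methylphenyl group with chlorine in place of its fluorine would speak to that. As far as these compounds go, it also remains open how this place would respond to a methoxy group or a nitrile in place of the halogen, and whether the same step would appear with the other ends of the molecule found in compound 2 or compound 3.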